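The source may report more compounds than this note shows. Statements on the series, on what has been measured and on what is new or still open speak of the compounds shown alone.

Measured compounds and values in a functional assay on PC-3 cells (Homo sapiens) for antiproliferative activity, read by MTT assay, with a stated time of 72 h; on this read-out higher numbers stand for weaker inhibition and lower numbers for stronger inhibition:
- compound 1 `Cc1ccc(C(C)C)c(OCCSC(=S)N[C@H]2CCOC2=O)c1`: > 64000 nM
- compound 2 `O=C(COc1ccc(C(=O)/C=C/c2ccccc2Cl)cc1)N[C@H]1CCOC1=O`: 4610 nM
- compound 3 `O=C1OCC[C@@H]1NC(=S)SCCOc1ccc([N+](=O)[O-])cc1`: 32500 nM

The value of compound 1 is a limit of this assay, not a number, as recorded in the limit of > 64000 nM in this assay, at which 1 of the 3 values shown sits. Of the two numbers, compound 2 stands lowest, and the gap to compound 3 lies beyond the scatter. Within the data shown here, no pair among the measured compounds differs in one place only, so no measured step is available.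

The unmeasured compound 4 `O=C(COc1ccc(C(=O)/C=C/c2ccc(Br)cc2)cc1)N[C@H]1CCOC1=O` is the single-point variant of compound 2, differing as follows:

4-bromophenyl in place of 2-chlorophenyl on a double-bonded chain carbon bound to a double-bonded chain carbon

The change exchanges one halogenated phenyl ring for another on the same double-bonded chain carbon; the rest of compound 2 is kept. Among the measured compounds shown here, nothing among the measured compounds shows what such an exchange does in this assay, so the expectation rests on compound 2 alone. The step from compound 2 to compound 4 is expected to be small in this assay, with no clear direction beyond the scatter, as a 1.0-fold lower number from compound 2 to compound 4 (0.01 log units; within the scatter). For compound 4 the estimate in this assay is 4500 nM, with a range from 1500 nM to 13000 nM.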

Compound 4, half-maximal inhibitory concentration: > 64000 nM
Compound 4 was reported as a limit; the forecaster's own chance of this, stated with the estimate: 5%; at least 14-fold (1.15 log units) between middle value and limit.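

In this assay, the place on a double-bonded chain carbon bound to a double-bonded chain carbon proves sensitive to the exchange of one halogenated phenyl ring for another: 4-bromophenyl in place of 2-chlorophenyl gives an at least 13-fold higher number from compound 2 to compound 4 (1.14 log units; beyond the scatter). The earlier compounds shown here offered no step at all, and this first one shows that the activity of compound 2 depends on the identity of this ring, even though the two groups match in their counts of heavy atoms, hydrogen-bond donors and hydrogen-bond acceptors. The result for compound 4 is a limit of the assay and not a number, and it is the same limit as for compound 1: the limit of > 64000 nM in this assay, at which 2 of the 4 values shown sit.

The compounds shown leave open whether the step follows the change of halogen or the change of its place on the ring, as both change together here, and a 4-chlorophenyl or an unsubstituted phenyl group on the same carbon would bear on that question. Going by these compounds, the full size of the step also stays open, since only its lower bound can be read.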